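Hydroxy to iodo on the anilide of compound 1

A few compounds are considered here, and "the series" means these few. Any claim that something is new, unique, unknown or untested is made for them only; others in the source may bear on it.

Compound 1 `Cn1c(Cc2nn(C)c(=O)c3ccccc23)nnc1SCC(=O)Nc1ccc(O)cc1` is the reference here; in an assay on isolated protein (Mus musculus) for inhibition of IL15-IL15 receptor (Homo sapiens), read by resazurin assay, with stated times of 30 min and 2.5 days (on this read-out higher numbers stand for weaker inhibition and lower numbers for stronger inhibition), compound 1 gives "not active" (no number reported), so no number stands for it. Compound 2 `Cn1c(Cc2nn(C)c(=O)c3ccccc23)nnc1SCCCCCCCC(=O)Nc1ccc(Cl)cc1Cl`, a differently built relative, gives 1900 nM in this assay. Compound 3 `Cn1c(Cc2nn(C)c(=O)c3ccccc23)nnc1SCC(=O)Nc1ccc(I)cc1` differs from compound 1 by iodo in place of hydroxy on an aromatic carbon. Among the measured compounds shown here, no step between measured compounds covers this change, so its size and direction are open. Because compound 1 gave "not active" (no number reported), no number exists from which the change to compound 3 could be counted, and weak or absent inhibition remains a plausible outcome for compound 3 as well. Compound 3 is expected near 6000 nM, within 1500 nM to 30000 nM.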

Compound 3, half-maximal inhibitory concentration: "not active" (no number reported)
Compound 3: no number reported, so the estimate cannot be set against anything.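

In this assay compound 1 gives "not active" (no number reported) and compound 3 gives "not active" (no number reported), so no step can be read between them. The compounds shown leave open what iodo in place of hydroxy does to inhibition. Nothing shown bears on a cause.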